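Swapping Trifluoromethoxy for Chloro on a Sulfonamide

The compounds below may be only part of what the source reports. "The series", "measured", "known", "first", "only" and "open" are said of these compounds alone.

Compound 1 `O=S(=O)(Nc1cccc(CO)c1)c1ccc(-c2ccc(F)cc2)cc1` gives 3500 nM in a functional assay on J774 cells (Mus musculus) for cytotoxicity, read by resazurin assay, with a stated time of 72 h; on this read-out lower numbers stand for stronger inhibition and higher numbers for weaker inhibition. For the measured compounds named here, compound 2 `O=S(=O)(Nc1cccc(CO)c1)c1ccc(-c2ccc(F)cc2)cc1OC(F)(F)F` gives 1000 nM in this assay, the lower of the two numbers; the single measured step, a 3.5-fold lower number from compound 1 to compound 2 (0.54 log units; beyond the scatter), separates them. Compound 3 `O=S(=O)(Nc1cccc(CO)c1)c1ccc(-c2ccc(F)cc2)cc1Cl` differs from compound 2 by chloro in place of trifluoromethoxy on an aromatic carbon. Going by the values given here, no measured step covers a chloro at that place, so the only guide is that the same position already shifted the number once. A modest rise back toward compound 1 is expected rather than a full return. The estimated step of a 1.8-fold higher number from compound 2 to compound 3 (0.26 log units; within the scatter) gives compound 3 an expected value of 1800 nM, with a likely range of 800 nM to 4000 nM.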

Compound 3, half-maximal inhibitory concentration: 1200 nM
Compound 3: the middle estimate sits 1.5-fold (0.18 log units) above what was measured; the measured number falls inside the stated range.
By their numbers in this assay, from the lowest: compounds 2 and 3 (each within the scatter of the next); then compound 1.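

In this assay, the lower number is not unique to trifluoromethoxy: chloro in place of hydrogen also gives a 2.9-fold lower number from compound 1 to compound 3 (0.46 log units; beyond the scatter). Replacing trifluoromethoxy with chloro gives a 1.2-fold higher number from compound 2 to compound 3 (0.08 log units; within the scatter), so these two quite different groups cannot be told apart at this place. No measurement shown here explains why they match. On these data alone, whether a methyl, a methoxy or an amine at this place would give a similar number remains open. For the compounds shown here, with only two groups to compare with hydrogen, what this place requires also remains unknown.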